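This account rests on a few compounds, and the source may have more. Where it says the series, first, only, none or still open, it means among the compounds named here.

Measured so far: compound 1 `CN1CCC[C@H]1COc1cncc(Cl)c1` with 0.6 nM in an assay on membranes from brain for displacement of a labelled ligand from Neuronal acetylcholine receptor; alpha4/beta2 (Rattus norvegicus); on this read-out higher numbers stand for weaker inhibition and lower numbers for stronger inhibition; compound 2 `CCCCCCc1cncc(OC[C@@H]2CCCN2C)c1` with 0.32 nM.

Among the compounds with values here, compound 2 has compound 1 as its only neighbour, and the step of a 1.9-fold lower number from compound 1 to compound 2 (0.27 log units; within the scatter) lies within the scatter. Compound 3 `CN1CCC[C@H]1COc1cncc([N+](=O)[O-])c1` is not yet measured; it differs from compound 2 by nitro in place of hexyl on an aromatic carbon. Within the data shown here, only the step of a 1.9-fold lower number from compound 1 to compound 2 (0.27 log units; within the scatter) bears on this change: exchanging chloro for hexyl on an aromatic carbon gave no shift beyond the scatter. For compound 3 no shift beyond the scatter is therefore expected, a 1.9-fold higher number from compound 2 to compound 3 (0.27 log units; within the scatter). Compound 3 is estimated at 0.6 nM, within 0.15 nM to 2.5 nM.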

Compound 3, inhibition constant: 4.65 nM
Estimate against measurement, compound 3: 7.8-fold (0.89 log units) below; measured number above the stated range.
By their numbers in this assay, from the lowest: compounds 2 and 1 (each within the scatter of the next); then compound 3.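

In this assay this aromatic carbon proves sensitive to the group it carries: nitro raises the number, with a 15-fold higher number from compound 2 to compound 3 (1.16 log units; beyond the scatter) and with a 7.8-fold higher number from compound 1 to compound 3 (0.89 log units; beyond the scatter) as well. Chloro and hexyl, though very different groups, had stayed within the scatter of each other, so the earlier pair gave no sign of this sensitivity. No data at hand account for the rise.

Going by these compounds, whether the rise is particular to nitro remains open. An amine, a nitrile or a carboxylic acid on the same carbon would test this, while a shorter alkyl chain would extend the comparison with hexyl.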